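The compounds below may be only part of what the source reports. "The series", "measured", "known", "first", "only" and "open" are said of these compounds alone.

Compound 1 `CCCCCCCNc1nc(SC)nc2ncccc12` carries a hexyl chain on a nitrogen of the shared core. Going by the values given here, in a functional assay (Nicotiana tabacum) (on this read-out lower numbers stand for stronger inhibition and higher numbers for weaker inhibition), compound 1 gives 4070 nM, the lowest of the three numbers measured so far. Compound 2 `CSc1nc(NC2CCCCC2)c2cccnc2n1` gives 5650 nM in this assay, a value within the scatter of that of compound 1. Among the compounds with values here, compound 3 `CCCCC(CC)CNc1nc(SC)nc2ncccc12` gives 15900 nM in this assay, and the step of a 3.9-fold higher number from compound 1 to compound 3 (0.59 log units; beyond the scatter) is the only single-point change measured, a modest weakening.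

Compound 4 `COCCNc1nc(SC)nc2ncccc12` has not been measured. It differs from compound 1 by methoxy in place of pentyl on a saturated chain carbon, two bonds along the chain from a nitrogen on an aromatic ring. Within the data shown here, no measured step bears directly on this change: the one known step concerns branching of the chain, not its length or an oxygen within it. The only movement seen beyond the scatter was toward weaker inhibition, and a weakening smaller than that of compound 3 is expected here. The expected step is a 2.5-fold higher number from compound 1 to compound 4 (0.39 log units; beyond the scatter). Compound 4 is therefore estimated to give about 10000 nM in this assay, with a range from 3000 nM to 35000 nM.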

Compound 4, half-maximal inhibitory concentration: 2530 nM
The estimate for compound 4 lay 4.0-fold (0.60 log units) above the measured number; the measured number lies below the stated range.
By their numbers in this assay, from the lowest: compounds 4, 1 and 2 (each within the scatter of the next, the first and the last beyond it); then compound 3.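

In this assay, methoxy in place of pentyl, on a saturated chain carbon two bonds along the chain from a nitrogen on an aromatic ring, gives a 1.6-fold lower number from compound 1 to compound 4 (0.21 log units; within the scatter), so the full hexyl chain is not needed to keep the inhibition seen with compound 1. The 2-methoxyethyl group also compares well with the other two groups: replacing cyclohexyl gives a 2.2-fold lower number from compound 2 to compound 4 (0.35 log units; beyond the scatter), and methoxymethyl in place of 1-ethylpentyl gives a 6.3-fold lower number from compound 3 to compound 4 (0.80 log units; beyond the scatter). No measurement shown here explains these differences.

This change shortens the chain and brings in an oxygen at once, so the effects of the two cannot be told apart. A plain butyl chain would help to separate them, while an amine or a carboxylic acid at the chain end remains an untested kind of group in this set.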